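Chain length beyond the carbonyl oxygen: working notes

This account rests on a few compounds, and the source may have more. Where it says the series, first, only, none or still open, it means among the compounds named here.

Measured so far:
compound 1 `CCCCOC(=O)CCC(=O)N1CCN(CCCOc2cc3c(Nc4ccc(F)c(Cl)c4)ncnc3cc2OC)CC1` gives 86% in a functional assay on A549 cells (Homo sapiens) for cytotoxicity, read by MTT assay, with a stated time of 24 h, tested at 20 uM; a lower number here means a stronger effect, a higher number a weaker effect of the compound at the concentration tested
compound 2 `CCCCCCOC(=O)CCC(=O)N1CCN(CCCOc2cc3c(Nc4ccc(F)c(Cl)c4)ncnc3cc2OC)CC1` gives 85.1% in this assay
compound 3 `CCCCCCCCCCCOC(=O)CCC(=O)N1CCN(CCCOc2cc3c(Nc4ccc(F)c(Cl)c4)ncnc3cc2OC)CC1` gives 85.2% in this assay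

Compound 3 stands second highest of the three numbers. Its nearest neighbour is compound 2, with a number 0.1 percentage points higher from compound 2 to compound 3 (within the scatter); its furthest is compound 1, with a number 0.8 percentage points lower from compound 1 to compound 3 (within the scatter). All three compounds sit within the scatter of one another in this assay, so no order among them can be read.

Compound 4 `CCCCCCCCCCCCCCCCOC(=O)CCC(=O)N1CCN(CCCOc2cc3c(Nc4ccc(F)c(Cl)c4)ncnc3cc2OC)CC1` differs from compound 3 by pentyl in place of hydrogen on a saturated chain carbon, ten or more bonds along the chain from an oxygen next to a carbonyl group. Among the compounds with values here, the steps that bear on this are the earlier chain extensions at the same tail: a number 0.9 percentage points lower from compound 1 to compound 2 (within the scatter), a number 0.8 percentage points lower from compound 1 to compound 3 (within the scatter) and a number 0.1 percentage points higher from compound 2 to compound 3 (within the scatter), none of them beyond the scatter. Lengthening the chain at this position has so far left this assay unchanged, and the same is expected here: the step from compound 3 to compound 4 is estimated at a number 0.2 percentage points lower from compound 3 to compound 4 (within the scatter), no change beyond the scatter.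

For compound 4 in this assay the expected value is 85%, with a range from 76% to 94%.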

Compound 4, a percentage reported as activity, at one concentration (the size of the read-out at that concentration, not a potency): 91.7%
The estimate for compound 4 lay 6.7 percentage points below the measured number, and the stated range covers the measured number.
By their numbers in this assay, from the lowest: compounds 2, 3, 1 and 4 (each within the scatter of the next).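

The longest tail in the set still gives no readable change in this assay: a number 6.5 percentage points higher from compound 3 to compound 4 (within the scatter), a number 6.6 percentage points higher from compound 2 to compound 4 (within the scatter) and a number 5.7 percentage points higher from compound 1 to compound 4 (within the scatter). These are the largest steps seen at this tail, yet the flat reading now holds across all four compounds, and no order among them can be read. Nothing measured alongside these compounds bears on the reason for this flat reading.

As far as these compounds go, all four compounds carry a plain saturated chain on the oxygen next to a carbonyl group, so the effect of an amine or a carboxylic acid at the end of that chain in this assay stays open. From the compounds shown here alone, a longer chain, or a tail ending in a phenyl ring, stays open as well.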